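Chloro for Fluoro on the Shared Core

This account rests on a few compounds, and the source may have more. Where it says the series, first, only, none or still open, it means among the compounds named here.

Of the compounds shown here, three have been tested in a functional assay on A549 cells (Homo sapiens) for cytotoxicity, read by MTT assay, with a stated time of 72 h; on this read-out higher numbers stand for weaker inhibition and lower numbers for stronger inhibition. Compound 1 `O=C(Nc1nc2ccc(F)cc2s1)c1cn(-c2ccccc2)nc1-c1ccccc1` gives 10200 nM. Compound 2 `O=C(Nc1nc2ccc(Cl)cc2s1)c1cn(-c2ccccc2)nc1-c1ccccc1` gives 7670 nM in this assay. Compound 3 `O=C(Nc1nc2ccc(F)cc2s1)c1cn(-c2ccccc2)nc1-c1ccc(Cl)cc1` gives 8860 nM in this assay. From compound 1 to compound 2 the change is chloro in place of fluoro on an aromatic carbon, and it made a 1.3-fold lower number from compound 1 to compound 2 (0.12 log units; within the scatter). Compound 3 differs from compound 1 by chloro in place of hydrogen on an aromatic carbon. Compound 4 `O=C(Nc1nc2ccc(Cl)cc2s1)c1cn(-c2ccccc2)nc1-c1ccc(Cl)cc1` carries the change (chloro in place of fluoro on an aromatic carbon), the same change as from compound 1 to compound 2, at the same place on the shared core. The step from compound 3 to compound 4 is expected to be a 1.3-fold lower number from compound 3 to compound 4 (0.11 log units; within the scatter), resting on the earlier pair because a 1.3-fold lower number from compound 1 to compound 2 (0.12 log units; within the scatter) lay within the scatter. Compound 4 is therefore estimated at 6800 nM in this assay, most likely between 3500 nM and 13000 nM.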

Compound 4, half-maximal inhibitory concentration: 4360 nM
For compound 4 the middle estimate is 1.6-fold (0.19 log units) above the measured one, within the range that was stated.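

In this assay, chloro in place of fluoro gives a 2.0-fold lower number from compound 3 to compound 4 (0.31 log units; beyond the scatter), and this step agrees with its earlier counterpart in direction and, within the scatter, in size: the same change on two cores in this assay, a 1.3-fold lower number (0.12 log units; within the scatter) from compound 1 to compound 2 and a 2.0-fold lower number (0.31 log units; beyond the scatter) from compound 3 to compound 4, 1.5-fold (0.18 log units) apart, within the scatter of two such steps. Chloro in place of hydrogen gives a 1.8-fold lower number from compound 2 to compound 4 (0.25 log units; within the scatter), and this step also matches its earlier counterpart: the same change on two cores in this assay, a 1.2-fold lower number (0.06 log units; within the scatter) from compound 1 to compound 3 and a 1.8-fold lower number (0.25 log units; within the scatter) from compound 2 to compound 4, 1.5-fold (0.18 log units) apart, within the scatter of two such steps. Within the data shown here, each change therefore carried over between these two cores, but each comparison rests on only two steps, so this shows neither an exact size for either change nor that it would hold on any other core.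

On these data alone, it remains open how an amine or a methoxy group on that aromatic carbon, in place of the chloro of compound 4, would read in this assay.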